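The compounds below may be only part of what the source reports. "The series", "measured", "known", "first", "only" and "open" are said of these compounds alone.

In a functional assay on MDA-MB-453 cells (Homo sapiens) for cytotoxicity, read by MTT assay, with a stated time of 72 h (a lower number here means a stronger inhibitor, a higher number a weaker inhibitor), compound 2 (`CC1=CCC[C@H]2[C@](C)(CC3=CC(=O)C=CC3=O)[C@@H](C)CC[C@]12C`) gives the lowest of the three measured numbers at 16700 nM, while compound 1 (`CC1=CCC[C@H]2[C@](C)(CC3=CC(=O)C(N4CCC[C@H]4C(=O)O)=CC3=O)[C@@H](C)CC[C@]12C`) gives 60600 nM and compound 3 (`CC(C)[C@@H](NC1=CC(=O)C=C(C(C)(C)C)C1=O)C(=O)O`) gives 133000 nM. The next entry is compound 4 (`CC1=CCC[C@H]2[C@](C)(CC3=CC(=O)C=C(N[C@@H](C)C(=O)O)C3=O)[C@@H](C)CC[C@]12C`), reached from compound 2 by (1-carboxyethyl)amino in place of hydrogen on a double-bonded ring carbon. Among the measured compounds shown here, the one measured step that bears on this is a 3.6-fold lower number from compound 1 to compound 2 (0.56 log units; beyond the scatter), a modest change where hydrogen replaces 2-carboxypyrrolidin-1-yl. Read in reverse, it suggests that adding the substituent raises the number, though the group differs here. A modest rise of similar size is expected in this assay, with the estimated step being a 2.5-fold higher number from compound 2 to compound 4 (0.40 log units; beyond the scatter). For compound 4 the estimate is 42000 nM, with an expected range of 17000 nM to 100000 nM.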

Compound 4, half-maximal inhibitory concentration: 14700 nM
The estimate for compound 4 lay 2.9-fold (0.46 log units) above the measured number, outside the stated range (below it).
By their numbers in this assay, from the lowest: compounds 4 and 2 (each within the scatter of the next); then compound 1; then compound 3.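

In this assay, a substituent on this double-bonded ring carbon, two ring bonds from the ring atom that bears a large group, need not shift the number: for (1-carboxyethyl)amino in place of hydrogen, the result is a 1.1-fold lower number from compound 2 to compound 4 (0.06 log units; within the scatter). The earlier step, a 3.6-fold lower number from compound 1 to compound 2 (0.56 log units; beyond the scatter), therefore does not extend to this group at this place. No available evidence accounts for the result. Open, on these data alone, is whether a methyl ester or a plain amine at the same ring carbon would behave alike, and whether a longer chain would.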